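A Trifluoromethyl Added to an Inactive Benzyl Ether

A few compounds are considered here, and "the series" means these few. Any claim that something is new, unique, unknown or untested is made for them only; others in the source may bear on it.

Values so far in a functional assay on HepG2 cells (Homo sapiens) for antiproliferative activity, read by MTT assay, with a stated time of 72 h; a higher number here means a weaker inhibitor, a lower number a stronger inhibitor
Compound 1 `c1ccc(COc2ccccc2Nc2ncnc3cc4c(cc23)OCCOCCO4)cc1` gives > 100000 nM (a limit)
Compound 2 `c1ccc(COc2ccc(Nc3ncnc4cc5c(cc34)OCCOCCOCCO5)cc2)cc1` gives > 100000 nM (a limit)

Within the data shown here, for compound 2, the only reading in this assay is > 100000 nM and this is a limit of the assay, not a number. The picture so far is simple, with both results the same limit: the limit of > 100000 nM in this assay, at which 2 of the 2 values shown sit (no measured number exists yet).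

Compound 3 `FC(F)(F)c1ccc(COc2ccc(Nc3ncnc4cc5c(cc34)OCCOCCOCCO5)cc2)cc1` differs from compound 2 in one place: trifluoromethyl in place of hydrogen on an aromatic carbon (a trifluoromethyl in place of hydrogen on an aromatic carbon). This turns benzyloxy into (4-(trifluoromethyl)benzyl)oxy, para to a large group.

Among the measured compounds shown here, no measured step shows how large such a change can be. A small step is expected in this assay and, if it can be read at all, it should point towards a stronger inhibitor. That expectation leans on compound 2 alone, whose > 100000 nM is a limit. The estimated change is an at least 1.2-fold lower number from compound 2 to compound 3 (0.09 log units; that floor lies within the scatter) (expected to be modest). For compound 3 the estimate is 80000 nM with an expected range from 25000 nM to 100000 nM (and the result may well be a limit again).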

Compound 3, half-maximal inhibitory concentration: > 100000 nM
Compound 3: only a limit was reported; the forecaster's own chance of this, stated with the estimate: 60%; at least 1.2-fold (0.09 log units) between middle value and limit.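

In this assay compound 3 gives > 100000 nM, which is a limit of the assay and not a number. Among these compounds, compound 2 also sits at a limit, so no step from compound 2 to compound 3 can be read. The compounds shown leave open what trifluoromethyl in place of hydrogen does to activity, and all share one reading: the limit of > 100000 nM in this assay, at which 3 of the 3 values shown sit.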